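The source may report more compounds than this note shows. Statements on the series, on what has been measured and on what is new or still open speak of the compounds shown alone.

In an ADME assay on MT4 cells (Homo sapiens) for cytotoxicity, read by MTT assay, with a stated time of 5 days (a higher number here means that more compound is tolerated, a lower number that less compound is tolerated), compound 1 (`Cc1cc(/C=C/C#N)cc(C)c1Oc1cc(NCCN(C)C)nc(Nc2ccc(C#N)cc2)n1`) gives 3040 nM, compound 2 (`Cc1cc(/C=C/C#N)cc(C)c1Oc1cc(NCCN(C)C)nc(Nc2ccc(C#N)cc2)c1`) gives 4270 nM and compound 3 (`Cc1cc(/C=C/C#N)cc(C)c1Oc1cc(NC2CC2)nc(Nc2ccc(C#N)cc2)n1`) gives 3000 nM. Compound 2 therefore lies within the scatter of both other compounds, and the three numbers cannot be told apart. Compound 4 (`COCCNc1cc(Oc2c(C)cc(/C=C/C#N)cc2C)cc(Nc2ccc(C#N)cc2)n1`) differs from compound 2 at one place, where 2-methoxyethyl stands in place of 2-(dimethylamino)ethyl: methoxy in place of dimethylamino on a saturated chain carbon, two bonds along the chain from a nitrogen on an aromatic ring. Going by the values given here, only one measured step touches this substituent. With cyclopropyl in place of 2-(dimethylamino)ethyl on a nitrogen on an aromatic ring, the data show a 1.0-fold lower number from compound 1 to compound 3 (0.01 log units; within the scatter). Among the compounds with values here, that step replaces the whole chain and lies within the scatter, while no measured pair compares methoxy with dimethylamino directly. No step beyond the scatter is therefore expected in this assay. The expected change is a 1.1-fold lower number from compound 2 to compound 4 (0.03 log units; within the scatter). For compound 4 the estimated value is 4000 nM, with an expected range from 1800 nM to 9000 nM.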

Compound 4, half-maximal cytotoxic concentration: 58200 nM
The estimate for compound 4 lay 15-fold (1.16 log units) below the measured number; measured number outside the range, above it.
By their numbers in this assay, from the lowest: compounds 3, 1 and 2 (each within the scatter of the next); then compound 4.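

In this assay the chain on the nitrogen turns out not to be indifferent to its end group, as a 14-fold higher number from compound 2 to compound 4 (1.13 log units; beyond the scatter) with methoxy in place of dimethylamino. Going by these compounds alone, the only earlier step on this substituent, a 1.0-fold lower number from compound 1 to compound 3 (0.01 log units; within the scatter), had replaced the whole 2-(dimethylamino)ethyl group with cyclopropyl and showed no change beyond the scatter. The present result therefore shows that a change confined to the end of the chain, on a saturated chain carbon, can matter far more at this position than that earlier step suggested.

Nothing among the data shown gives a reason for this step. From the compounds shown here alone, it also remains open whether the higher number belongs to methoxy in particular or would also appear with another end group, such as a hydroxyl, a primary amine or a morpholine, or with a longer chain carrying methoxy.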